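Compound 3: 2-Bromophenyl in Place of 2-Methoxyphenyl

A few compounds are considered here, and "the series" means these few. Any claim that something is new, unique, unknown or untested is made for them only; others in the source may bear on it.

Among the compounds with values here, in a functional assay on A549 cells (Homo sapiens) for inhibition, read by MTT assay, with a stated time of 24 h (on this read-out lower numbers stand for stronger inhibition of growth and higher numbers for weaker inhibition of growth), compound 1 `COc1ccccc1C(=O)n1c(-c2cn(C)c3ccccc23)nc2ccccc21` gives 12300 nM and compound 2 `COc1ccc2c(c1)c(-c1nc3ccccc3n1C(=O)c1ccccc1OC)cn2C` gives 11900 nM, so compound 2 stands level with its only measured neighbour. Compound 3 `COc1ccc2c(c1)c(-c1nc3ccccc3n1C(=O)c1ccccc1Br)cn2C` carries bromo in place of methoxy on an aromatic carbon, ortho to a large group (bromo in place of methoxy on an aromatic carbon). Within the data shown here, the one measured step, a 1.0-fold lower number from compound 1 to compound 2 (0.01 log units; within the scatter), concerns a different change, methoxy in place of hydrogen, so it offers only weak guidance. The expected step is small, a 1.2-fold lower number from compound 2 to compound 3 (0.08 log units; within the scatter), with no shift beyond the scatter anticipated. For compound 3 the estimated value is 10000 nM, within a range of 4500 nM to 22000 nM.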

Compound 3, concentration for 50% growth inhibition: 29500 nM
For compound 3 the middle estimate is 3.0-fold (0.47 log units) below the measured one; measured number outside the range, above it.
By their numbers in this assay, from the lowest: compounds 2 and 1 (each within the scatter of the next); then compound 3.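

In this assay, bromo in place of methoxy on this aromatic carbon gives a 2.5-fold higher number from compound 2 to compound 3 (0.39 log units; beyond the scatter), meaning weaker inhibition of growth. This is the first change among these compounds to move the number beyond the scatter, whereas methoxy in place of hydrogen between compound 1 and compound 2 did not. No measurement here accounts for the difference between bromo and methoxy. The compounds shown leave open how an amine or a carboxylic acid on this aromatic carbon would fare. Going by these compounds, whether fluoro would track bromo or methoxy also stays open.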